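A few compounds are considered here, and "the series" means these few. Any claim that something is new, unique, unknown or untested is made for them only; others in the source may bear on it.

Compound 1 `Fc1ccc(C2CC(c3ccccc3)=NN2c2ccc(-c3ccccc3)nn2)cc1`, compound 2 `Fc1ccc(C2CC(c3ccc(Cl)cc3)=NN2c2ccc(-c3ccccc3)nn2)cc1` and compound 3 `COc1ccc(C2=NN(c3ccc(-c4ccccc4)nn3)C(c3ccc(F)cc3)C2)cc1` have been measured. In a functional assay on Caco-2 cells (Homo sapiens) for antiproliferative activity, read by MTT assay, with a stated time of 24 h (on this read-out higher numbers stand for weaker inhibition and lower numbers for stronger inhibition), compound 1 gives 10000 nM. Compound 2 reaches only a limit of the assay, > 100000 nM. Compound 3 gives 18100 nM. Among the two numbers shown, compound 3 holds the highest, with compound 1 nearest: a 1.8-fold higher number from compound 1 to compound 3 (0.26 log units; within the scatter). Compound 4 `COc1ccc(C2=NN(c3ccc(-c4ccccc4)nn3)C(c3ccc(OC)cc3OC)C2)cc1` differs from compound 3 by 2,4-dimethoxyphenyl in place of 4-fluorophenyl on a saturated ring carbon. The measured steps, an at least 10-fold higher number from compound 1 to compound 2 (1.00 log units; beyond the scatter), a 1.8-fold higher number from compound 1 to compound 3 (0.26 log units; within the scatter) and an at least 5.5-fold lower number from compound 2 to compound 3 (0.74 log units; beyond the scatter), all act on an aromatic carbon; none touches the saturated ring carbon, so they give no direct guide to this change. Without a bearing step, the expected step is a 1.1-fold higher number from compound 3 to compound 4 (0.04 log units; within the scatter), within the scatter. Compound 4 is therefore estimated at 20000 nM, between 6000 nM and 70000 nM.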

Compound 4, half-maximal inhibitory concentration: > 100000 nM
Compound 4 was reported as a limit; the forecaster's own chance of this, stated with the estimate: 15%; middle value at least 5.0-fold (0.69 log units) from the limit.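

In this assay, the saturated ring carbon responds to a change of its aryl group: 2,4-dimethoxyphenyl in place of 4-fluorophenyl gives an at least 5.5-fold higher number from compound 3 to compound 4 (0.74 log units; beyond the scatter), the only step at this position among the compounds shown. Compound 4 reads only as a limit, so this step gives a bound and not an exact size: the limit of > 100000 nM in this assay, at which 2 of the 4 values shown sit.

As far as these compounds go, whether a single methoxy group on this phenyl ring would read the same remains open. So does how an amine or a carboxylic acid at this position would read.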